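A few compounds are considered here, and "the series" means these few. Any claim that something is new, unique, unknown or untested is made for them only; others in the source may bear on it.

Measured in a functional assay on Huh-7 cells (Homo sapiens) for cytotoxicity, read by MTT assay, with a stated time of 72 h; a lower number here means that less compound is tolerated, a higher number that more compound is tolerated:
- compound 1 `CCCCS(=O)(=O)N1CCC2(CC1)OOC1(CCCC1)OO2`: > 100 ug/mL, a limit
- compound 2 `CCCCS(=O)(=O)N1CCC2(CC1)OOC1(CCCCCC1)OO2`: > 100 ug/mL, a limit
- compound 3 `O=S(=O)(CCCCl)N1CCC2(CC1)OOC1(CCCCC1)OO2`: > 100 ug/mL, a limit

Compound 2 has no numerical value, since its > 100 ug/mL is a limit. The record so far is the limit of > 100 ug/mL in this assay, at which 3 of the 3 values shown sit, and gives no number for any compound. Going by these compounds, its true standing among the three therefore remains unknown.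

The next compound is compound 4 `O=S(=O)(c1ccc(Br)cc1F)N1CCC2(CC1)OOC1(CCCCCC1)OO2`, which alters the group on the sulfonyl sulfur of compound 2. The change is 4-bromo-2-fluorophenyl in place of butyl on a sulfonyl sulfur and amounts to 4-bromo-2-fluorophenyl in place of butyl on a sulfonyl sulfur. For the measured compounds named here, none of the measured compounds carries an aromatic ring at this place, and no measured pair shows the size of such a change.

With compound 2 at > 100 ug/mL as the only starting point, a modest move towards less compound being tolerated is expected, though a result within the scatter would not be surprising. The expected change is an at least 1.2-fold lower number from compound 2 to compound 4 (0.09 log units; that floor lies within the scatter) and is an estimate measured against a limit. Compound 4 is estimated at 80 ug/mL, with an expected range of 25 ug/mL to 150 ug/mL, and a further limit instead of a number is about as likely.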

Compound 4, half-maximal cytotoxic concentration: > 100 ug/mL
Compound 4: a limit, no number (the forecaster's own chance of this, stated with the estimate: 50%); middle value at least 1.2-fold (0.09 log units) from the limit.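

In this assay compound 4 gives > 100 ug/mL, a limit. Compound 2 gives > 100 ug/mL, also a limit, so the step to compound 4 cannot be read. The compounds shown leave open where any of them would reach a half-maximal cytotoxic concentration, and whether the group on the sulfonyl sulfur alters it: the limit of > 100 ug/mL in this assay, at which 4 of the 4 values shown sit.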